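Changing the Aryl Halide and Expected Tolerance

The source may report more compounds than this note shows. Statements on the series, on what has been measured and on what is new or still open speak of the compounds shown alone.

Compound 2 `O=c1[nH]cc(S(=O)(=O)Nc2ccc(-c3cn(-c4ccccc4F)nn3)cc2)c(=O)[nH]1` has been examined in an ADME assay on L02 cells (Homo sapiens) for cytotoxicity, read by MTT assay, with a stated time of 24 h; a higher number here means that more compound is tolerated, a lower number that less compound is tolerated. For compound 2 the result is only a limit of the assay, > 100000 nM, and not a number. Compound 1 `Cc1ccc(-n2cc(-c3ccc(NS(=O)(=O)c4c[nH]c(=O)[nH]c4=O)cc3)nn2)cc1` in this assay is recorded as "not toxic" (no number reported), again without a figure. Compound 2 therefore stands at the limit of > 100000 nM in this assay, at which 1 of the 2 values shown sits, the only numerical mark in this small set. Compound 3 `O=c1[nH]cc(S(=O)(=O)Nc2ccc(-c3cn(-c4cccc(Cl)c4)nn3)cc2)c(=O)[nH]1` has not yet been measured. It differs from compound 2 in one place: 3-chlorophenyl in place of 2-fluorophenyl on an aromatic nitrogen. Among the compounds with values here, no step between two measured compounds is available, so no size or direction of change can be read from the data. Compound 3 is expected to stay at the limit in this assay, and the step of a number no higher from compound 2 to compound 3 (the limit leaves the size open) is estimated to lie within the scatter. Compound 3 is estimated at 100000 nM, with a range from 50000 nM to 200000 nM.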

Compound 3, half-maximal cytotoxic concentration: 19000 nM
Estimate against measurement, compound 3: 5.3-fold (0.72 log units) above; measured number below the stated range.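

In this assay, within the data shown here, 3-chlorophenyl in place of 2-fluorophenyl on an aromatic nitrogen gives an at least 5.2-fold lower number from compound 2 to compound 3 (0.72 log units; beyond the scatter), the first change in this set that can be read. This position is therefore not indifferent to the aryl group it carries, and compound 3 is the only compound shown with a single number. That step gives only a minimum size, because compound 2 stands at a limit of the assay and not at a number: the limit of > 100000 nM in this assay, at which 1 of the 3 values shown sits.

The halogen and its place on the ring change together, so the compounds shown cannot say which of the two matters, and 3-fluorophenyl or 2-chlorophenyl would be needed to separate them. From the compounds shown here alone, compound 1, recorded as "not toxic" (no number reported), cannot be ranked against compound 3, and how a 3-aminophenyl group would fare at this position stays open.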